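The compounds below may be only part of what the source reports. "The series", "measured", "known", "first", "only" and "open" are said of these compounds alone.

Series notes. Compound 2 `CCOC(=O)c1ccc(/N=N/N(C)C(=O)OCOC(C)=O)cc1` is the lower of the two measured compounds in an ADME assay on a cell-free system (plasma, Homo sapiens) for metabolic stability; a lower number here means that the compound disappears faster, a higher number that the compound lasts longer: compound 2 gives 0.2 h, and compound 1 `CCOC(=O)c1ccc(/N=N/N(C)C(=O)OCOC(=O)c2ccccc2)cc1` gives 0.783 h. Within the data shown here, the one measured step, a 3.9-fold lower number from compound 1 to compound 2 (0.59 log units; beyond the scatter), comes from methyl in place of phenyl on a carbonyl carbon.

The next compound, compound 3 `CCOC(=O)c1ccc(/N=N/N(C)C(=O)OCOC(=O)c2ccccc2OC(C)=O)cc1`, differs from compound 2 by 2-acetoxyphenyl in place of methyl on a carbonyl carbon, on a carbonyl carbon whose other neighbours are oxygen next to a carbonyl group. The bearing step is again the methyl-to-aryl exchange at this carbonyl; compound 1 shows where an aryl ester of this kind stands, and the step from compound 1 to compound 2 was modest but beyond the scatter. An increase from compound 2 is therefore expected, likely of a similar size, as a 2.5-fold higher number from compound 2 to compound 3 (0.40 log units; beyond the scatter). For compound 3 the estimate in this assay is 0.5 h, with a range of 0.2 h to 1.2 h.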

Compound 3, half-life: 0.0167 h
Beside the measured number, compound 3's estimate is 30-fold (1.48 log units) above it; measured number below the stated range.
By their numbers in this assay, from the lowest: compound 3; then compound 2; then compound 1.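

In this assay, an aryl group at this carbonyl does not by itself give a higher number: the phenyl of compound 1 stands above the methyl of compound 2, yet the exchange to 2-acetoxyphenyl gives a 12-fold lower number from compound 2 to compound 3 (1.08 log units; beyond the scatter), which reverses the order expected from the earlier pair. Among these compounds, at the aromatic ring, the single change of acetoxy in place of hydrogen on an aromatic carbon gives a 47-fold lower number from compound 1 to compound 3 (1.67 log units; beyond the scatter), so this position is far more sensitive to substitution on the aryl group than the earlier pair could show. Nothing available here bears on the reason for this drop.

The compounds shown leave open whether a methoxy, a hydroxyl or a carboxylic acid in place of the acetoxy would give a step of similar size. Also open, from the compounds shown here alone, is how a longer chain in place of the methyl within the acetoxy would read.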